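Fluoro on the phenyl: a cytotoxicity step in Vero cells

A few compounds are considered here, and "the series" means these few. Any claim that something is new, unique, unknown or untested is made for them only; others in the source may bear on it.

Compound 1 has the structure `C[C@]1(CN2CCc3nc(-c4ccccc4)ccc3C2)Cn2cc([N+](=O)[O-])nc2O1`. In an ADME assay on Vero cells (Chlorocebus sabaeus) for cytotoxicity, read by MTT assay, with a stated time of 72 h (a higher number here means that more compound is tolerated, a lower number that less compound is tolerated), compound 1 gives > 32 ug/mL, which is a limit of the assay and not a number. Two companions share the same core and the same nitroimidazole-oxazine part. Compound 2, `C[C@]1(CN2CCc3oc(-c4ccc(F)cc4)nc3C2)Cn2cc([N+](=O)[O-])nc2O1`, reaches > 32 ug/mL, again a limit rather than a number. Compound 3, `C[C@]1(CN2CCc3sc(-c4ccc(F)cc4)nc3C2)Cn2cc([N+](=O)[O-])nc2O1`, has "not determined" (no result reported) in this assay, so no result stands for it. Compound 1 therefore sits where (the limit of > 32 ug/mL in this assay, at which 2 of the 3 values shown sit), with no single number of its own.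

The step under study leads from compound 1 to compound 4, whose structure is `C[C@]1(CN2CCc3nc(-c4ccccc4F)ccc3C2)Cn2cc([N+](=O)[O-])nc2O1`. The change is fluoro in place of hydrogen on an aromatic carbon: fluoro enters on an aromatic carbon of a six-membered aromatic ring of carbon only, ortho to a large group, so that phenyl becomes 2-fluorophenyl. Within the data shown here, no step between measured compounds is available to weigh this change, and the two values that do exist are both limits. He expects no shift beyond the usual scatter in this assay, since compound 1 and compound 2 both stop at the same limit, and the step that the limit leaves unreadable from compound 1 to compound 4 is estimated to be essentially flat. For compound 4 he estimates 40 ug/mL in this assay, within a range from 20 ug/mL to 80 ug/mL, most likely reported again only as a limit.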

Compound 4, half-maximal cytotoxic concentration: > 32 ug/mL
Compound 4 gave a limit, no number (the forecaster's own chance of this, stated with the estimate: 80%); the middle value lies beyond the limit too.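

Among these compounds, compound 4, like compound 1, stops at a limit in this assay, so no step from compound 1 to compound 4 can be read for 2-fluorophenyl in place of phenyl. The compounds shown leave open where the tolerated concentrations of compound 1 and compound 4 actually lie, since their results reach only this limit: the limit of > 32 ug/mL in this assay, at which 3 of the 4 values shown sit.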